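Aryl ether and thioether variation on a diamine core

The source may report more compounds than this note shows. Statements on the series, on what has been measured and on what is new or still open speak of the compounds shown alone.

Measured so far in a functional assay on RXF 393 cells (Homo sapiens) for inhibition, read by sulforhodamine B assay, with a stated time of 48 h; on this read-out lower numbers stand for stronger inhibition of growth and higher numbers for weaker inhibition of growth:
compound 1 `Nc1cc(N)c2nc(-c3ccccc3)c(Oc3ccc(Cl)c(Cl)c3)nc2c1`: 58900 nM
compound 2 `CCOC(=O)[C@H](CCC(=O)O)NC(=O)c1ccc(Oc2nc3cc(N)cc(N)c3nc2-c2ccccc2)cc1`: 20000 nM
compound 3 `COc1ccc(Sc2nc3cc(N)cc(N)c3nc2-c2ccccc2)cc1`: 17000 nM

Compound 3 gives the lowest number of the three. Its nearest neighbour is compound 2, whose value lies within the scatter of that of compound 3, so no order between these two can be stated. For the measured compounds named here, compound 1 stands furthest away; the step of a 3.5-fold lower number from compound 1 to compound 3 (0.54 log units; beyond the scatter) is the only one-place change measured so far and is modest but beyond the scatter.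

Compound 4 `Nc1cc(N)c2nc(-c3ccccc3)c(Oc3ccc(F)cc3)nc2c1` is not yet measured. It differs from compound 3 by 4-fluorophenoxy in place of (4-methoxyphenyl)sulfanyl on an aromatic carbon. Going by the values given here, the one measured step bears on this change only partly: it traded a dichlorophenoxy group for a methoxyphenylsulfanyl group and lowered the number, whereas compound 4 returns to an aryl ether, now carrying a single fluorine. The value of compound 4 is therefore expected to move back toward that of compound 1, giving a step of a 1.8-fold higher number from compound 3 to compound 4 (0.25 log units; within the scatter) in this assay, of modest size and likely within or just beyond the scatter. Compound 4 is estimated at 30000 nM, with a range from 12000 nM to 75000 nM.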

Compound 4, concentration for total growth inhibition: < 100000 nM
Compound 4 gave a limit, no number (the forecaster's own chance of this, stated with the estimate: 10%); the middle value does not contradict the limit.
By their numbers in this assay, from the lowest: compounds 3 and 2 (each within the scatter of the next); then compound 1.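

In this assay compound 4 gives < 100000 nM, which is a limit and not a number. The steps to compound 4 from compound 1 and compound 3 cannot be read. As far as these compounds go, how 4-fluorophenoxy compares with 3,4-dichlorophenoxy and (4-methoxyphenyl)sulfanyl on the shared core stays open.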